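A few compounds are considered here, and "the series" means these few. Any claim that something is new, unique, unknown or untested is made for them only; others in the source may bear on it.

Measured compounds in a functional assay on MOLT-4 cells (Homo sapiens) for cytotoxicity, read by CCK-8 assay, with a stated time of 72 h; on this read-out higher numbers stand for weaker inhibition and lower numbers for stronger inhibition:
Compound 1 `C=CCn1c(=O)/c(=C\c2cccc(C)c2)[nH]c(=O)/c1=C\c1ccccc1OC`, which gives 16000 nM.
Compound 3 `C=CCn1c(=O)/c(=C\c2cccc(Br)c2)[nH]c(=O)/c1=C\c1ccccc1OC`, which gives 5000 nM.
Compound 2 `COc1ccccc1/C=c1/[nH]c(=O)/c(=C\c2ccccc2OC)[nH]c1=O`, for which the entry reads "not determined" (no result reported), so no number was reported.

On the numbers at hand, compound 1 stands highest of the two that were measured; its nearest neighbour is compound 3, and the change from a methyl to a bromo on an aromatic carbon gave a 3.2-fold lower number from compound 1 to compound 3 (0.51 log units; beyond the scatter), a modest move toward stronger inhibition.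

The step now followed leads from compound 1 to compound 4 `C=CCn1c(=O)/c(=C\c2ccccc2OC)[nH]c(=O)/c1=C\c1ccccc1OC`. The change is 2-methoxyphenyl in place of 3-methylphenyl on a double-bonded chain carbon bound to an aromatic carbon. Among the measured compounds shown here, no measured pair mirrors this exchange: the only step recorded concerns a different substituent on that same aryl ring, and compound 2, which carries the 2-methoxyphenyl on both sides of the core, has no number. The step in this assay is therefore expected to stay within the scatter, with no clear direction, and compound 4 is estimated at 12000 nM (range 4000 nM to 40000 nM), an expected 1.3-fold lower number from compound 1 to compound 4 (0.12 log units; within the scatter).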

Compound 4, half-maximal inhibitory concentration: 13100 nM
Compound 4: the middle estimate sits 1.1-fold (0.04 log units) below what was measured, within the range that was stated.
By their numbers in this assay, from the lowest: compound 3; then compounds 4 and 1 (each within the scatter of the next).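

In this assay, 2-methoxyphenyl in place of 3-methylphenyl on a double-bonded chain carbon bound to an aromatic carbon gives a 1.2-fold lower number from compound 1 to compound 4 (0.09 log units; within the scatter), so the assay does not separate these two groups at this place, even though the entering group holds an oxygen that the leaving group lacks. Set against the bromo compound, the same group gives a 2.6-fold higher number from compound 3 to compound 4 (0.42 log units; beyond the scatter), which makes 3-bromophenyl the only one of the three aryl groups shown here to stand apart, with the lowest number. No measurement at hand accounts for this difference.

The compounds shown leave open whether the lower number of compound 3 is particular to bromo or would also appear with a chloro or an amine in its place on that aryl ring. They also leave open how far this holds for a longer chain at the same carbon.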